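The source may hold more compounds than are shown below. What is called first, only, known or untested is meant among the compounds shown, and "the series" means these compounds.

Measured so far:
- compound 1 `O=S1(=O)C=Cc2ccc(Nc3ccc(Cl)cc3)cc21` at 6720 nM
- compound 2 `O=S1(=O)C=Cc2cccc(Nc3ccc(C(F)(F)F)cc3)c21` at 1200 nM

In a functional assay on MDA-MB-231 cells (Homo sapiens) for antiproliferative activity, read by MTT assay, with a stated time of 72 h (a lower number here means a stronger inhibitor, a higher number a weaker inhibitor), compound 2 gives 1200 nM as the lower of the two numbers, and the gap to compound 1 at 6720 nM lies beyond the scatter. Among the measured compounds shown here, no measured pair differs in one place only, so no direct step is available as a guide.

The next compound is compound 3 `COc1ccc(Nc2cccc3c2S(=O)(=O)C=C3)cc1` with methoxy in place of trifluoromethyl on an aromatic carbon, para to a large group: methoxy in place of trifluoromethyl on an aromatic carbon. Nothing measured yet shows what this exchange does in this assay so the expectation is loose. A moderately higher number than that of compound 2 is expected, with a step not far beyond the scatter. For the measured compounds named here, the upper side of this expectation leans on compound 1 at 6720 nM as the only other number. The estimated step of a 2.1-fold higher number from compound 2 to compound 3 (0.32 log units; beyond the scatter) is therefore expected to point towards weaker inhibition. For compound 3 the estimate is 2500 nM with an expected range of 800 nM to 8000 nM as the working figure.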

Compound 3, half-maximal inhibitory concentration: 1040 nM
Beside the measured number, compound 3's estimate is 2.4-fold (0.38 log units) above it, and the stated range covers the measured number.
By their numbers in this assay, from the lowest: compounds 3 and 2 (each within the scatter of the next); then compound 1.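

In this assay, among the compounds shown here, methoxy in place of trifluoromethyl on an aromatic carbon, para to a large group, gives a 1.2-fold lower number from compound 2 to compound 3 (0.06 log units; within the scatter) and provides the first direct reading of a single change. At this position, the read-out does not separate methoxy, with 2 heavy atoms and 1 hydrogen-bond acceptor, from trifluoromethyl, with 4 heavy atoms and 0 hydrogen-bond acceptors, so this difference in make-up carries no detectable penalty or gain for this pair. The data at hand offer no measurement that would account for this outcome.

From the compounds shown here alone, it remains open whether the same holds for an amine, a carboxylic acid or a longer alkoxy chain on this aromatic carbon, since a single pair cannot show how far the position accepts other groups. Compound 1 differs from compound 2 and from compound 3 in more than one place, so the separate contributions of its chlorine and of its different attachment to the core remain unresolved.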